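Halogen Swaps Across a Shared Core

The source may report more compounds than this note shows. Statements on the series, on what has been measured and on what is new or still open speak of the compounds shown alone.

Four compounds share one core and differ only in the halogen carried on each of two phenyl rings. Compound 1 `NC(=O)c1c(NC(=O)c2ccccc2Cl)sc2c1CCN(C(=S)Nc1ccccc1F)C2` carries a chloro on the 2-chlorophenyl ring joined through the carbonyl and a fluoro on the 2-fluorophenyl ring joined through the amino group. In a functional assay on HeLa cells (Homo sapiens) for antiproliferative activity, with a stated time of 24 h (on this read-out lower numbers stand for stronger inhibition and higher numbers for weaker inhibition), compound 1 gives 28700 nM. Compound 2 `NC(=O)c1c(NC(=O)c2ccccc2Cl)sc2c1CCN(C(=S)Nc1ccccc1Br)C2` differs from compound 1 by bromo in place of fluoro on an aromatic carbon, and in this assay compound 2 gives 24600 nM; the step is a 1.2-fold lower number from compound 1 to compound 2 (0.07 log units; within the scatter). Compound 3 `NC(=O)c1c(NC(=O)c2ccccc2Br)sc2c1CCN(C(=S)Nc1ccccc1F)C2` differs from compound 1 by bromo in place of chloro on an aromatic carbon. For compound 3 this assay reports only a limit, > 50000 nM, which is the limit (the limit of > 50000 nM in this assay, at which 1 of the 3 values shown sits). The step is an at least 1.7-fold higher number from compound 1 to compound 3 (0.24 log units; that floor lies within the scatter). Compound 4 `NC(=O)c1c(NC(=O)c2ccccc2Br)sc2c1CCN(C(=S)Nc1ccccc1Br)C2` has not yet been measured; it differs from compound 3 by bromo in place of fluoro on an aromatic carbon, the same change as from compound 1 to compound 2, at the same place. Because that change gave a 1.2-fold lower number from compound 1 to compound 2 (0.07 log units; within the scatter), compound 4 is expected to stay close to compound 3, with an expected step that the limit leaves unreadable from compound 3 to compound 4. Compound 4 is estimated at 60000 nM, between 30000 nM and 150000 nM, and it seems likely that this assay again reports only a limit.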

Compound 4, half-maximal inhibitory concentration: 24700 nM
For compound 4 the middle estimate is 2.4-fold (0.39 log units) above the measured one; measured number below the stated range.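

Changing fluoro to bromo on the ring joined through the amino group gives, in this assay, an at least 2.0-fold lower number from compound 3 to compound 4 (0.30 log units; that floor lies within the scatter), and setting this beside the same change on the core of compound 1 gives no clear verdict: the same change on two cores in this assay, a 1.2-fold lower number (0.07 log units; within the scatter) from compound 1 to compound 2 and an at least 2.0-fold lower number (0.30 log units; that floor lies within the scatter) from compound 3 to compound 4; the limit leaves it open whether they differ. Changing chloro to bromo on the ring joined through the carbonyl gives a 1.0-fold higher number from compound 2 to compound 4 (0.00 log units; within the scatter), and this comparison is equally unsettled: the same change on two cores in this assay, an at least 1.7-fold higher number (0.24 log units; that floor lies within the scatter) from compound 1 to compound 3 and a 1.0-fold higher number (0.00 log units; within the scatter) from compound 2 to compound 4; the limit leaves it open whether they differ. Compound 3 stands at a limit, > 50000 nM, so these pairs show neither that either change keeps its size from one core to another nor that its size shifts.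

The compounds shown leave open the actual number for compound 3 and how a chloro on the ring joined through the amino group would read in this assay. They also leave open how a methoxy group or an amine would read in place of the halogen on either ring.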